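This account rests on a few compounds, and the source may have more. Where it says the series, first, only, none or still open, it means among the compounds named here.

Compound 1 `O=S(=O)(NCCCCNCc1ccc(Br)cc1)c1cc(C(F)(F)F)cc(C(F)(F)F)c1` gives 2900 nM in a functional assay on ASPC1 cells (Homo sapiens) for inhibition, read by MTT assay, with a stated time of 72 h (a higher number here means a weaker inhibitor of growth, a lower number a stronger inhibitor of growth), the lowest of the two numbers measured, while compound 2 `CN(CCCNS(=O)(=O)c1cc(C(F)(F)F)cc(C(F)(F)F)c1)Cc1ccccc1` gives 51000 nM in this assay. Compound 3 `O=S(=O)(NCCCNCc1ccc(Cl)cc1)c1cc(C(F)(F)F)cc(C(F)(F)F)c1` differs from compound 1 by (4-chlorobenzyl)amino in place of ((4-bromobenzyl)amino)methyl on a saturated chain carbon, three bonds along the chain from a sulfonamide nitrogen. Among the measured compounds shown here, the one measured step that bears on this change, an 18-fold higher number from compound 1 to compound 2 (1.25 log units; beyond the scatter), also shortened the chain at this place, but altered the amine in a different way, so only part of it carries over. A smaller weakening is therefore expected, a 2.1-fold higher number from compound 1 to compound 3 (0.32 log units; beyond the scatter). Compound 3 is estimated at 6000 nM, with a range from 2500 nM to 15000 nM.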

Compound 3, concentration for 50% growth inhibition: 3000 nM
Compound 3: the middle estimate sits 2.0-fold (0.30 log units) above what was measured; measured number inside the range.
By their numbers in this assay, from the lowest: compounds 1 and 3 (each within the scatter of the next); then compound 2.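

In this assay, (4-chlorobenzyl)amino in place of ((4-bromobenzyl)amino)methyl gives a 1.0-fold higher number from compound 1 to compound 3 (0.01 log units; within the scatter), so this position accepts the swap with no measurable difference. Compound 2 carries the benzyl(methyl)amino group instead, and a 17-fold lower number from compound 2 to compound 3 (1.23 log units; beyond the scatter) shows that the shorter chain alone does not account for its high number. Nothing measured here explains these numbers.

Chain length and halogen changed together between compound 1 and compound 3, so their separate contributions remain unknown. A 4-chlorobenzyl group on the longer chain would separate them, and a methyl on the amine nitrogen of compound 3 would test that methyl group with the chlorine kept.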